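Swapping the acyl aryl group on a trifluoromethyl-thiazole acylurea

The source may hold more compounds than are shown below. What is called first, only, known or untested is meant among the compounds shown, and "the series" means these compounds.

Three compounds share one core, an acylurea joined to a thiazole that carries an acylhydrazone arm. Compound 1 `Cc1nc(N(C)C(=O)NC(=O)c2c(F)cccc2F)sc1C(=O)N/N=C/c1ccc(C(F)(F)F)cc1` bears a methyl on the thiazole and a 2,6-difluorophenyl on the acyl end; in a functional assay on MCF7 cells (Homo sapiens) for inhibition, read by MTT assay, with a stated time of 72 h (on this read-out higher numbers stand for weaker inhibition and lower numbers for stronger inhibition), compound 1 gives 30.6 ug/mL. Compound 2 `CN(C(=O)NC(=O)c1ccc(C(F)(F)F)cc1)c1nc(C(F)(F)F)c(C(=O)N/N=C/c2ccc(C(F)(F)F)cc2)s1` carries a trifluoromethyl on the thiazole and a 4-(trifluoromethyl)phenyl on the acyl end. In this assay compound 2 reaches only a limit, > 100 ug/mL, so no number is known for it (the limit of > 100 ug/mL in this assay, at which 1 of the 2 values shown sits). Compound 3 `CN(C(=O)NC(=O)c1c(F)cccc1F)c1nc(C(F)(F)F)c(C(=O)N/N=C/c2ccc(C(F)(F)F)cc2)s1` is compound 2 with one change: 2,6-difluorophenyl in place of 4-(trifluoromethyl)phenyl on a carbonyl carbon. Because compound 2 stands at the limit of > 100 ug/mL in this assay, at which 1 of the 2 values shown sits, the size of the step from compound 2 to compound 3 cannot be pinned down. Compound 1 carries the same 2,6-difluorophenyl on the acyl end and gives 30.6 ug/mL, and on that ground compound 3 is expected to show a step of about an at least 1.6-fold lower number from compound 2 to compound 3 (0.22 log units; that floor lies within the scatter). Compound 3 is therefore estimated at 60 ug/mL, within 25 ug/mL to 150 ug/mL.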

Compound 3, half-maximal inhibitory concentration: 35.3 ug/mL
Estimate against measurement, compound 3: 1.7-fold (0.23 log units) above, and the stated range covers the measured number.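

In this assay, 2,6-difluorophenyl in place of 4-(trifluoromethyl)phenyl on a carbonyl carbon gives an at least 2.8-fold lower number from compound 2 to compound 3 (0.45 log units; beyond the scatter), which shows that the aryl group on the acyl end matters when the core carries trifluoromethyl. Only a floor can be given for this step, and the reason is that compound 2 stands at a limit: the limit of > 100 ug/mL in this assay, at which 1 of the 3 values shown sits. With 2,6-difluorophenyl held on the acyl end, trifluoromethyl in place of methyl on an aromatic carbon gives a 1.2-fold higher number from compound 1 to compound 3 (0.06 log units; within the scatter), so compound 1 and compound 3 cannot be told apart in this read-out.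

The compounds shown leave open what a plain phenyl, a 2-fluorophenyl or a 4-methoxyphenyl would give on the same carbonyl carbon. Also open, from the compounds shown here alone, is whether an ethyl or a chlorine on that aromatic carbon would match methyl and trifluoromethyl.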